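Swapping cyano for nitro on compound 3

The source may hold more compounds than are shown below. What is called first, only, known or untested is meant among the compounds shown, and "the series" means these compounds.

In a functional assay on CWR22R cells (Homo sapiens) for antiproliferative activity, read by propidium iodide staining, with a stated time of 96 h (a higher number here means a weaker inhibitor, a lower number a stronger inhibitor), compound 1 (`CC(O)(COc1ccc(C#N)cc1)C(=O)Nc1ccc(S(F)(F)(F)(F)F)cc1`) gives 26100 nM and compound 2 (`CC(O)(COc1ccc(C#N)c(F)c1)C(=O)Nc1ccc(S(F)(F)(F)(F)F)cc1`) gives 24300 nM while compound 3 (`CC(O)(CS(=O)(=O)c1ccc(S(F)(F)(F)(F)F)cc1)C(=O)Nc1ccc(C#N)cc1C(F)(F)F`) gives 19400 nM and so stands level with both, all three values lying within the scatter of one another. Compound 4 (`CC(O)(CS(=O)(=O)c1ccc(S(F)(F)(F)(F)F)cc1)C(=O)Nc1ccc([N+](=O)[O-])cc1C(F)(F)F`) has not yet been measured. It differs from compound 3 in one place: nitro in place of cyano on an aromatic carbon, meta to a trifluoromethyl group and para to a large group (nitro in place of cyano on an aromatic carbon). Within the data shown here, no measured pair makes this exchange. Among the measured compounds shown here, the only measured single change is fluoro in place of hydrogen on an aromatic carbon (a 1.1-fold lower number from compound 1 to compound 2 (0.03 log units; within the scatter)), which stayed within the scatter but is a different swap and so offers only weak guidance. No step beyond the scatter is therefore expected in this assay and the expected step is small (a 1.0-fold higher number from compound 3 to compound 4 (0.01 log units; within the scatter)). Compound 4 is estimated at 20000 nM (expected range 9000 nM to 40000 nM).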

Compound 4, half-maximal inhibitory concentration: 18700 nM
Compound 4: the middle estimate sits 1.1-fold (0.03 log units) above what was measured, within the range that was stated.
By their numbers in this assay, from the lowest: compounds 4, 3, 2 and 1 (each within the scatter of the next).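

In this assay, nitro in place of cyano, on the aromatic carbon para to a large group and meta to a trifluoromethyl group, gives a 1.0-fold lower number from compound 3 to compound 4 (0.02 log units; within the scatter), which lies within the scatter. Among these compounds, this is the first exchange seen at this position, and it shows that a nitro group with 3 heavy atoms and 2 hydrogen-bond acceptors can stand in for a cyano group with 2 heavy atoms and 1 acceptor without a step this assay can separate from repeat-measurement noise. No measurement is available that explains why the two compounds read alike.

From the compounds shown here alone, it remains open whether an amine or a carboxylic acid on this same carbon would also stay within the scatter of compound 3. Also open, going by these compounds, is whether nitro in place of cyano would do the same on compound 1.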